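Ring size at the amine substituent, cyclobutyl to cyclohexyl

This account rests on a few compounds, and the source may have more. Where it says the series, first, only, none or still open, it means among the compounds named here.

Compound 1, `CC(C)(C)CN1CCc2c(sc(NC(=O)Nc3ccc(Cl)cc3)c2C(N)=O)C1`: 5560 nM
Compound 2, `CCN1CCc2c(sc(NC(=O)Nc3ccc(Cl)cc3)c2C(N)=O)C1`: 3120 nM
Compound 3, `NC(=O)c1c(NC(=O)Nc2ccc(Cl)cc2)sc2c1CCN(CC1CCC1)C2`: 1360 nM

In a functional assay (strain AB) with Danio rerio as the target, read by microscopy, with a stated time of 1 h (a lower number here means that less compound is needed, a higher number that more compound is needed for the effect), compound 3 stands lowest of the three numbers. The steps of a 4.1-fold lower number from compound 1 to compound 3 (0.61 log units; beyond the scatter) and a 2.3-fold lower number from compound 2 to compound 3 (0.36 log units; beyond the scatter) both lie beyond the scatter, whereas a 1.8-fold lower number from compound 1 to compound 2 (0.25 log units; within the scatter) does not. Compound 4, `NC(=O)c1c(NC(=O)Nc2ccc(Cl)cc2)sc2c1CCN(CC1CCCCC1)C2`, differs from compound 3 by cyclohexyl in place of cyclobutyl on a saturated chain carbon bound to an amine nitrogen in a ring. The measured steps bear on it only loosely: a tert-butyl gave higher numbers, while a cyclobutyl gave a lower number than methyl, so the direction for a larger ring is not settled. Compound 4 is therefore expected to sit close to compound 3, with a step of a 1.1-fold lower number from compound 3 to compound 4 (0.05 log units; within the scatter) that is not expected to exceed the scatter. The estimate for compound 4 in this assay is 1200 nM, within a range of 400 nM to 3600 nM.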

Compound 4, half-maximal effective concentration: 1890 nM
Compound 4: the middle estimate sits 1.6-fold (0.20 log units) below what was measured; low and high end bracket the measured number.
By their numbers in this assay, from the lowest: compounds 3, 4, 2 and 1 (each within the scatter of the next, the first and the last beyond it).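

In this assay, cyclohexyl in place of cyclobutyl on this saturated chain carbon gives a 1.4-fold higher number from compound 3 to compound 4 (0.14 log units; within the scatter), so the larger ring cannot be told apart from the smaller one at this place. Cyclohexyl also stays within the scatter of methyl, with a 1.7-fold lower number from compound 2 to compound 4 (0.22 log units; within the scatter), but separates from tert-butyl, with a 2.9-fold lower number from compound 1 to compound 4 (0.47 log units; beyond the scatter), so both rings now stand clear of tert-butyl, while compound 2, with methyl, goes against any simple split between rings and open chains, as it lies within the scatter of both compound 1 and compound 4. Nothing available explains these numbers.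

Going by these compounds, how a cyclopentyl group would fall at this place remains open. So does whether a ring carrying an amine or a carboxylic acid would stay within the same narrow spread.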